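This account rests on a few compounds, and the source may have more. Where it says the series, first, only, none or still open, it means among the compounds named here.

Measured so far in an ADME assay on the whole organism for inhibition, with Echinochloa crus-galli var. formosensis as the target, with a stated time of 4 days; on this read-out lower numbers stand for stronger inhibition and higher numbers for weaker inhibition:
Compound 1 `CC[C@H](C)Nc1nc(Cl)nc(N[C@@H](C)c2ccccc2)n1` gives 14100 nM as its value
Compound 2 `CC[C@H](C)Nc1nc(Cl)nc(N[C@H](C)c2ccccc2)n1` gives 52500 nM as its value
Compound 3 `CC[C@@H](C)Nc1nc(Cl)nc(N[C@@H](C)c2ccccc2)n1` gives 7410 nM as its value

Compound 2 (52500 nM) has the highest number of the three and is the weakest inhibitor here, beyond the scatter from both others. Compound 4 `CC(C)N(c1nc(Cl)nc(N[C@H](C)c2ccccc2)n1)C(C)C` has diisopropylamino in place of (sec-butyl)amino on an aromatic carbon.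

Going by the values given here, no measured step makes this replacement, since all three compare configurations only. They offer only a scale. Inverting the sec-butyl stereocentre gives a 1.9-fold lower number from compound 1 to compound 3 (0.28 log units; within the scatter) and stays within the scatter, while a 3.7-fold higher number from compound 1 to compound 2 (0.57 log units; beyond the scatter) and a 7.1-fold lower number from compound 2 to compound 3 (0.85 log units; beyond the scatter) are modest. The larger of these, from compound 2 to compound 3 (a 7.1-fold lower number from compound 2 to compound 3 (0.85 log units; beyond the scatter)), marks the widest spread seen so far, so a modest step is expected here too. Its direction is a judgement from the structural change alone, and a weaker result is expected. The expected change in this assay is a 2.3-fold higher number from compound 2 to compound 4 (0.36 log units; beyond the scatter) in this estimate. The estimate for compound 4 is 120000 nM (expected range 35000 nM to 400000 nM).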

Compound 4, half-maximal inhibitory concentration: 6610 nM
Compound 4: the middle estimate sits 18-fold (1.26 log units) above what was measured; measured number outside the range, below it.
By their numbers in this assay, from the lowest: compounds 4, 3 and 1 (each within the scatter of the next, the first and the last beyond it); then compound 2.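

In this assay, the replacement of (sec-butyl)amino by diisopropylamino gives a 7.9-fold lower number from compound 2 to compound 4 (0.90 log units; beyond the scatter), the first change shown in the group itself, since the earlier steps varied configuration alone. Compound 4 has 0 hydrogen-bond donors and no defined stereocentre in this group, so neither the donor nor the stereocentre of (sec-butyl)amino is required for inhibition at this level, at least with the remainder of compound 2 in place. Nothing in the available evidence bears on why this step goes in this direction.

The compounds shown leave open whether the donor count or the larger group goes with the change, which a group such as N-methyl-(sec-butyl)amino could separate. They also leave open how diisopropylamino behaves with the opposite configuration in the remainder of the molecule, and how smaller dimethylamino or a cyclic amine such as piperidine compares.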